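Aryl exchange at the shared core: thiophene for naphthalene

A few compounds are considered here, and "the series" means these few. Any claim that something is new, unique, unknown or untested is made for them only; others in the source may bear on it.

The shared core carries an aromatic group at one carbon; in compound 1 `c1ccc2c(-c3cn4ccnc4c(-c4ccc5ncn(C6CCCCC6)c5c4)n3)cccc2c1` this group is naphthalen-1-yl. In a functional assay on KM12 cells (Homo sapiens) for inhibition, read by sulforhodamine B assay, with a stated time of 48 h, tested at 10 uM (on this read-out lower numbers stand for less inhibition and higher numbers for more inhibition at the one concentration tested (going by the name of the read-out)), compound 1 gives 11.1%. Compound 2 `CC(=O)c1ccc(-c2cn3ccnc3c(-c3ccc4ncn(C5CCCCC5)c4c3)n2)cc1` gives 11.7% and compound 3 `Clc1ccc(-c2cn3ccnc3c(-c3ccc4ncn(C5CCCCC5)c4c3)n2)cc1` gives 10.6% in this assay. Compound 1 sits between the other two on these numbers, with a number 0.5 percentage points lower from compound 1 to compound 3 (within the scatter) as its nearest neighbour and a number 0.6 percentage points higher from compound 1 to compound 2 (within the scatter) as its furthest; a number 1.1 percentage points lower from compound 2 to compound 3 (within the scatter) likewise stays within the scatter, so none of the three can be told apart.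

Compound 4 `c1csc(-c2cn3ccnc3c(-c3ccc4ncn(C5CCCCC5)c4c3)n2)c1` differs from compound 1 in one place: thiophen-2-yl in place of naphthalen-1-yl on an aromatic carbon. Among the compounds with values here, the steps that bear on this change are the two other group exchanges at the same aromatic carbon, 4-acetylphenyl and 4-chlorophenyl each replacing naphthalen-1-yl, and both stayed within the scatter. For compound 4 the expected step is a number 0.1 percentage points lower from compound 1 to compound 4 (within the scatter), not beyond the scatter, because a number 0.6 percentage points higher from compound 1 to compound 2 (within the scatter) and a number 0.5 percentage points lower from compound 1 to compound 3 (within the scatter) gave no movement either. Compound 4 is therefore expected to give 11% in this assay, within a range from 2% to 22%.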

Compound 4, a percentage reported as inhibition, at one concentration (the size of the read-out at that concentration, not a potency): 4.89%
Compound 4: middle estimate off by 6.1 percentage points, on the high side; low and high end bracket the measured number.
By their numbers in this assay, from the lowest: compounds 4, 3, 1 and 2 (each within the scatter of the next).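

In this assay, thiophen-2-yl at this aromatic carbon gives a number 6.2 percentage points lower from compound 1 to compound 4 (within the scatter), with a number 5.7 percentage points lower from compound 3 to compound 4 (within the scatter) and a number 6.8 percentage points lower from compound 2 to compound 4 (within the scatter). The position therefore accepts a single five-membered aromatic ring with a sulfur atom as well as naphthalen-1-yl, 4-acetylphenyl and 4-chlorophenyl, and the four compounds cannot be told apart, even with this change from two fused carbon rings to one ring with a hetero atom. Nothing on hand gives a reason for these numbers.

Going by these compounds, it remains open whether an amine or a carboxylic acid on the aromatic group at this carbon would move the number beyond the scatter. On these data alone, the cyclohexyl group elsewhere on the shared core also stays constant across these compounds, so its contribution remains open, and a single-concentration read-out gives no potency for any of them.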